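Changing the Halogenated Phenyl Group on an Aromatic Nitrogen

This account rests on a few compounds, and the source may have more. Where it says the series, first, only, none or still open, it means among the compounds named here.

Of the compounds shown here, three sharing one core have been tested in a functional assay on HepG2 cells (Homo sapiens) for inhibition, read by MTT assay, with a stated time of 72 h; a lower number here means a stronger inhibitor, a higher number a weaker inhibitor. Compound 1 `CCc1cccc(-n2cc(COc3cccc(NC(=O)Nc4ccc(Cl)c(C(F)(F)F)c4)c3)nn2)c1` gives 37900 nM, compound 2 `O=C(Nc1cccc(OCc2cn(-c3ccccc3Br)nn2)c1)Nc1ccc(Cl)c(C(F)(F)F)c1` gives 2810 nM, and compound 3 `O=C(Nc1cccc(OCc2cn(-c3cccc(Br)c3)nn2)c1)Nc1ccc(Cl)c(C(F)(F)F)c1` gives 1040 nM, the lowest of the three numbers. Compound 4 `O=C(Nc1cccc(OCc2cn(-c3ccc(I)cc3)nn2)c1)Nc1ccc(Cl)c(C(F)(F)F)c1` differs from compound 3 in one place: 4-iodophenyl in place of 3-bromophenyl on an aromatic nitrogen. Among the compounds with values here, two measured steps bear on this change: a 36-fold lower number from compound 1 to compound 3 (1.56 log units; beyond the scatter), and a 2.7-fold lower number from compound 2 to compound 3 (0.43 log units; beyond the scatter). Both show that the group on the aromatic nitrogen matters, but neither involves 4-iodophenyl, so the direction of the new step is uncertain. A modest change is therefore expected, a 1.4-fold higher number from compound 3 to compound 4 (0.16 log units; within the scatter). Compound 4 is estimated at 1500 nM, within a range from 500 nM to 5000 nM.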

Compound 4, half-maximal inhibitory concentration: 2690 nM
For compound 4 the middle estimate is 1.8-fold (0.25 log units) below the measured one, within the range that was stated.
By their numbers in this assay, from the lowest: compound 3; then compounds 4 and 2 (each within the scatter of the next); then compound 1.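

Swapping to 4-iodophenyl gives no gain over 3-bromophenyl in this assay, with a 2.6-fold higher number from compound 3 to compound 4 (0.41 log units; beyond the scatter), while 4-iodophenyl and 2-bromophenyl cannot be told apart, with a 1.0-fold lower number from compound 2 to compound 4 (0.02 log units; within the scatter). Within the data shown here, both still sit well clear of 3-ethylphenyl, with a 14-fold lower number from compound 1 to compound 4 (1.15 log units; beyond the scatter), so this is the first sign that a halogenated phenyl other than 2-bromophenyl or 3-bromophenyl also outperforms it. No measurement here accounts for these differences.

The halogen and its place on the ring change together, so their separate contributions remain unresolved. As far as these compounds go, how a phenyl ring carrying an amine or a carboxylic acid would behave also stays open.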